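A few compounds are considered here, and "the series" means these few. Any claim that something is new, unique, unknown or untested is made for them only; others in the source may bear on it.

Working notes on the series. For the measured compounds named here, in an ADME assay on HEK-293T cells (Homo sapiens) for cytotoxicity, read by MTT assay, with a stated time of 24 h (on this read-out higher numbers stand for lower toxicity in this test and lower numbers for higher toxicity in this test), compound 1 (`O=S(=O)(c1ccccc1)n1c(-c2cn(-c3ccccc3)nc2-c2ccc(F)cc2)nc2ccccc21`) gives 96300 nM and compound 2 (`COc1ccc(S(=O)(=O)n2c(-c3cn(-c4ccccc4)nc3-c3ccc(F)cc3)nc3ccccc32)cc1`) gives 37300 nM (the lower of the two numbers so far). Compound 3 (`Cc1ccc(C)c(S(=O)(=O)n2c(-c3cn(-c4ccccc4)nc3-c3ccc(F)cc3)nc3ccccc32)c1`) has not been measured. Its difference from compound 2 is 2,5-dimethylphenyl in place of 4-methoxyphenyl on a sulfonyl sulfur.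

Going by the values given here, only one measured step bears on this change: a 2.6-fold lower number from compound 1 to compound 2 (0.41 log units; beyond the scatter) (methoxy in place of hydrogen on an aromatic carbon). It is modest but beyond the scatter, and it shows that the group on the sulfonyl sulfur can shift the number. Among the compounds with values here, it is a single step, however, and no measured compound carries 2,5-dimethylphenyl. Compound 3 has no methoxy, and neither does compound 1 (96300 nM), so a number between those of the two measured compounds is expected in this assay. The direction is expected to be slightly upward, with a size no larger than the measured step and probably not beyond the scatter. The expected step is a 1.3-fold higher number from compound 2 to compound 3 (0.13 log units; within the scatter) (an estimate). For compound 3 the estimated value is 50000 nM (expected range 20000 nM to 110000 nM).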

Compound 3, half-maximal cytotoxic concentration: 54200 nM
For compound 3 the middle estimate is 1.1-fold (0.04 log units) below the measured one; measured number inside the range.
By their numbers in this assay, from the lowest: compounds 2, 3 and 1 (each within the scatter of the next, the first and the last beyond it).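

In this assay, 2,5-dimethylphenyl on the sulfonyl sulfur gives a 1.5-fold higher number from compound 2 to compound 3 (0.16 log units; within the scatter) and a 1.8-fold lower number from compound 1 to compound 3 (0.25 log units; within the scatter) as its two readings against the measured compounds. The earlier step showed only that adding methoxy to the phenyl group on this sulfur could move the number beyond the scatter; compound 3 shows that a carbon-only aryl group with two methyl groups can stand here and remain within the scatter of both compound 1 and compound 2, even though those two lie beyond the scatter of each other. No measurement on record gives a reason for these numbers.

Still open, on these data alone, is whether a group of another kind on the sulfonyl sulfur, such as an aminophenyl, a carboxyphenyl or a saturated alkyl chain, would stand beyond the scatter of all three compounds. Also open, as far as these compounds go, is whether a single methyl group at either of the positions in 2,5-dimethylphenyl would read differently from the two together, since the present compounds do not separate them.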